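The source may report more compounds than this note shows. Statements on the series, on what has been measured and on what is new or still open speak of the compounds shown alone.

Measured so far:
- compound 1 `CC(C)[C@H](NC(=O)COc1cccc2ccccc12)C(=O)N[C@@H](CC(=O)O)C(=O)COc1ccc(F)c(F)c1`: > 100000 nM
- compound 2 `CC(C)[C@H](NC(=O)COc1cccc2ccccc12)C(=O)N[C@@H](CC(=O)O)C(=O)COc1cc(F)c(F)cc1F`: 39300 nM
- compound 3 `CC(C)[C@H](NC(=O)COc1cccc2ccccc12)C(=O)N[C@@H](CC(=O)O)C(=O)COc1c(Cl)cccc1Cl`: 3000 nM

All three were tested in a functional assay on Jurkat cells (Homo sapiens); on this read-out lower numbers stand for stronger inhibition and higher numbers for weaker inhibition. The entry for compound 1, > 100000 nM, is a limit of the assay and not a number. Compound 3 stands lowest of the three at 3000 nM.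

Compound 4 `CC(C)[C@H](NC(=O)COc1cccc2ccccc12)C(=O)N[C@@H](CC(=O)O)C(=O)COc1cccc(C(F)(F)F)c1F` keeps the shared core and changes only the group on the oxygen: 2-fluoro-3-(trifluoromethyl)phenyl in place of 2,6-dichlorophenyl on an oxygen on a saturated carbon. Chlorine leaves and fluorine enters. The closest evidence comes from two measured swaps of a fluorinated phenyl for 2,6-dichlorophenyl: a 13-fold lower number from compound 2 to compound 3 (1.12 log units; beyond the scatter) and an at least 33-fold lower number from compound 1 to compound 3 (1.52 log units; beyond the scatter). Both are large. Fluorinated rings also differ among themselves, as an at least 2.5-fold lower number from compound 1 to compound 2 (0.40 log units; beyond the scatter) shows, so the size of the change is uncertain. Compound 4 goes the opposite way, from 2,6-dichlorophenyl to a fluorinated ring, so a higher number is expected, meaning weaker inhibition. The expected change is a 5.0-fold higher number from compound 3 to compound 4 (0.70 log units; beyond the scatter). For compound 4 the estimated value is 15000 nM, with an expected range of 3500 nM to 70000 nM.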

Compound 4, half-maximal inhibitory concentration: 50400 nM
Compound 4: the middle estimate sits 3.4-fold (0.53 log units) below what was measured, and the stated range covers the measured number.
By their numbers in this assay, from the lowest: compound 3; then compounds 2 and 4 (each within the scatter of the next). At a limit, above all of these: compound 1.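

In this assay the move to 2-fluoro-3-(trifluoromethyl)phenyl costs a large amount of inhibition (a 17-fold higher number from compound 3 to compound 4 (1.23 log units; beyond the scatter)), so a fluorinated ring that also carries trifluoromethyl does not match the 2,6-dichlorophenyl group on this oxygen. Among the fluorinated rings, 2,4,5-trifluorophenyl and 2-fluoro-3-(trifluoromethyl)phenyl cannot be told apart (a 1.3-fold higher number from compound 2 to compound 4 (0.11 log units; within the scatter)), so adding trifluoromethyl shows no measurable gain or loss against that ring. The entry for compound 1 is a limit of the assay, so the step that starts from it gives only a floor (an at least 1.9-fold lower number from compound 1 to compound 4 (0.29 log units; that floor lies within the scatter)) and sets no order: the limit of > 100000 nM in this assay, at which 1 of the 4 values shown sits.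

Within the data shown here, compound 3 is the only chlorinated compound here, so it stays open whether the chlorine atoms themselves or their placement on the ring set its lower number. A 2,6-difluorophenyl or a 3,4-dichlorophenyl group on the same oxygen would help to separate these two readings.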